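The compounds below may be only part of what the source reports. "The series", "measured", "known", "first", "only" and "open" are said of these compounds alone.

Compound 1 `O=C(NCCCCC(c1ccc(F)cc1)c1ccc(F)cc1)Nc1ccc(I)cc1` gives 11800 nM
Compound 2 `O=C(NCCCCC(c1ccc(F)cc1)c1ccc(F)cc1)Nc1cccc(Cl)c1` gives 5070 nM

In a functional assay on MDA-MB-231 cells (Homo sapiens) for cytotoxicity, read by MTT assay, with a stated time of 48 h (on this read-out lower numbers stand for stronger inhibition and higher numbers for weaker inhibition), compound 2 stands lowest of the two, at 5070 nM, and so serves as the starting point. Compound 3 `Cc1cccc(NC(=O)NCCCCC(c2ccc(F)cc2)c2ccc(F)cc2)c1` differs from it by a single swap, methyl in place of chloro on an aromatic carbon, meta to a large group: methyl in place of chloro on an aromatic carbon. Among the measured compounds shown here, the only measured step that bears on this is modest, a 2.3-fold lower number from compound 1 to compound 2 (0.37 log units; beyond the scatter), and it involves a different change, so no direct precedent for this swap exists. No step beyond the scatter is expected, with a slight lean towards a higher number. The estimated step is a 1.3-fold higher number from compound 2 to compound 3 (0.11 log units; within the scatter). In this assay compound 3 is estimated at 6500 nM, with an expected range of 2800 nM to 15000 nM.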

Compound 3, half-maximal inhibitory concentration: > 20000 nM
Compound 3: only a limit was reported; the forecaster's own chance of this, stated with the estimate: 3%; middle value at least 3.0-fold (0.48 log units) away from the limit.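

In this assay compound 3 gives only a limit, not a number: the limit of > 20000 nM in this assay, at which 1 of the 3 values shown sits.
Methyl in place of chloro on this aromatic carbon, meta to a large group, is therefore no neutral exchange of one heavy atom, with an at least 3.9-fold higher number from compound 2 to compound 3 (0.59 log units; beyond the scatter), and chloro is the better of the two groups here. Against the 4-iodophenyl group the floor is smaller, at an at least 1.6-fold higher number from compound 1 to compound 3 (0.22 log units; that floor lies within the scatter), and that floor alone does not separate the two compounds.

The compounds shown leave open how fluoro, bromo or trifluoromethyl at this position would compare with chloro. They also leave open how chloro would fare at the position that iodo holds in compound 1.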